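Swapping the Aryl Ether for an Aryl Thioether

A few compounds are considered here, and "the series" means these few. Any claim that something is new, unique, unknown or untested is made for them only; others in the source may bear on it.

Going by the values given here, in a functional assay on OVCAR-8 cells (Homo sapiens) for inhibition, read by sulforhodamine B assay, with a stated time of 48 h (on this read-out lower numbers stand for higher toxicity in this test and higher numbers for lower toxicity in this test), compound 2 `Nc1cc(N)c2nc(-c3ccccc3)c(Oc3ccc(F)cc3)nc2c1` gives 100000 nM, the only outright number among the three measured compounds. Compound 1 `CCOC(=O)[C@H](CCC(=O)O)NC(=O)c1ccc(Sc2nc3cc(N)cc(N)c3nc2-c2ccccc2)cc1` reaches only a limit of the test, < 100000 nM. Compound 3 `CCOC(=O)[C@H](CCC(=O)O)NC(=O)c1ccc(CNc2nc3cc(N)cc(N)c3nc2-c2ccccc2)cc1` likewise stops at a limit, < 100000 nM; two of the three values therefore sit at the limit of < 100000 nM in this assay, at which 2 of the 3 values shown sit. Compound 4 `COc1ccc(Sc2nc3cc(N)cc(N)c3nc2-c2ccccc2)cc1` has not yet been measured; it differs from compound 2 by (4-methoxyphenyl)sulfanyl in place of 4-fluorophenoxy on an aromatic carbon. Among the compounds with values here, no step between two measured compounds is available, so the size of this change must be judged from the three values alone: the expected step of a 2.0-fold lower number from compound 2 to compound 4 (0.30 log units; within the scatter) is modest, toward greater toxicity, and barely beyond the scatter. Compound 4 is estimated at 50000 nM, within 15000 nM to 150000 nM, with a fair chance that this assay again reports only a limit.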

Compound 4, concentration lethal to 50% of the cells: < 100000 nM
Compound 4 gave a limit, no number; the forecaster's own chance of this, stated with the estimate: 45%; the middle value is on the limit's open side.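

In this assay compound 4 gives < 100000 nM as a limit of the test and not a number. Putting (4-methoxyphenyl)sulfanyl in place of 4-fluorophenoxy on this aromatic carbon gives a number no higher from compound 2 to compound 4 (the limit leaves the size open) and so shows a direction, while the size of the step cannot be read. The readings now crowd at a single edge of the test: the limit of < 100000 nM in this assay, at which 3 of the 4 values shown sit.

Going by these compounds, the sulfur and the methoxy group arrive together, so their separate shares stay open. On these data alone, what an amine or a carboxylic acid in place of the methoxy group would do also remains open.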